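This account rests on a few compounds, and the source may have more. Where it says the series, first, only, none or still open, it means among the compounds named here.

Measured so far:
compound 1, `N#C[C@@H]1CCCN1C(=O)[C@@H]1C[C@H](C(=O)N2CCCCC2)CN1`, in an assay on the whole organism (plasma, strain Sprague-Dawley) for inhibition of Dipeptidyl peptidase 4 (Rattus norvegicus), with a stated time of 10 h, at a dose of 1 mg/kg by the oral route (a lower number here means less inhibition, a higher number more inhibition at the dose given (going by the name of the read-out)), gives 50%.
compound 2, `N#C[C@@H]1CCCN1C(=O)[C@@H]1C[C@H](C(=O)N2CCCCCC2)CN1`, in this assay gives "not determined" (no result reported).

Compound 2 therefore stands without a single number in this assay; only compound 1 offers a measured figure. The next compound is compound 3, `N#C[C@@H]1CCCN1C(=O)[C@@H]1C[C@H](C(N)=O)CN1`. It differs from compound 2 by amino in place of azepan-1-yl on a carbonyl carbon. For the measured compounds named here, with no step between measured compounds to lean on, the step to compound 3 in this assay is expected to be of moderate size at most, with no direction that can be told apart from the scatter. Compound 3 is estimated to give 40%, within 15% to 70%.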

Compound 3, a percentage reported as inhibition, in the whole organism at one dose (the size of the read-out at that dose, not a potency): 20%
For compound 3 the middle estimate is 20 percentage points above the measured one; low and high end bracket the measured number.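

In this assay the group on this carbonyl carbon now has a readable comparison: amino in place of piperidin-1-yl gives a number 30 percentage points lower from compound 1 to compound 3 (beyond the scatter) and so the read-out at this place responds to the change. The step from compound 2 cannot be read, as azepan-1-yl has no number. Nothing measured here accounts for the step.

As far as these compounds go, it remains open whether a smaller cyclic amine such as pyrrolidin-1-yl or an open-chain dimethylamino group would keep the read-out of compound 1 or fall towards that of compound 3.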